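A few compounds are considered here, and "the series" means these few. Any claim that something is new, unique, unknown or untested is made for them only; others in the source may bear on it.

Working notes on the pyrazoline series.

Compound 3 `COc1cc(C)c(Cl)cc1C1=NN(c2ccc(S(N)(=O)=O)cc2)C(/C=C/c2ccccc2)C1` stands at 55.3% in a functional assay on the whole organism (strain Wistar) for inhibition, with Rattus norvegicus as the target, read by paw edema, with stated times of 30 min and 3 h, at a dose of 20 mg/kg by the oral route; on this read-out lower numbers stand for less inhibition and higher numbers for more inhibition at the one dose given (going by the name of the read-out). On that read-out compound 3 sits level with compound 2 `COc1cc(C)c(Cl)cc1C1=NN(c2ccc(S(N)(=O)=O)cc2)C(c2ccccc2)C1`, which gives 55.3% in this assay; the two together hold the lowest numbers among the three measured. Compound 1 `COc1ccc(C2CC(c3cc(Cl)c(C)cc3O)=NN2c2ccc(S(N)(=O)=O)cc2)c(OC)c1OC`, which carries a trimethoxyphenyl on the saturated ring carbon while the other two aryl groups sit the other way round, gives 68.4% in this assay, a number beyond the scatter above compound 3.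

The step to compound 4 `COc1cc(C)c(Cl)cc1C1=NN(c2ccc(S(N)(=O)=O)cc2)C(c2ccc(OC)c(OC)c2OC)C1` is 2,3,4-trimethoxyphenyl in place of 2-phenylethenyl on a saturated ring carbon. Within the data shown here, the one measured step at this position, no change at the digits printed from compound 2 to compound 3 (within the scatter), shows that swapping one hydrocarbon substituent for another left the inhibition unchanged. Among the measured compounds shown here, no measured step places a trimethoxyphenyl on this carbon within the present core, so the step to compound 4 has no direct precedent; compound 1 shows only that a trimethoxyphenyl on the saturated ring carbon is compatible with the highest number seen, in a different arrangement of the other groups.

On this basis a small rise, not clearly beyond the scatter, is expected for compound 4, a step of a number 5.7 percentage points higher from compound 3 to compound 4 (within the scatter) in this assay. The estimate for compound 4 is 61%, in the range 50% to 72%.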

Compound 4, a percentage reported as inhibition, in the whole organism at one dose (the size of the read-out at that dose, not a potency): 34.2%
The estimate for compound 4 lay 26.8 percentage points above the measured number, and the stated range ends above it.
By their numbers in this assay, from the lowest: compound 4; then compounds 2 and 3 (each within the scatter of the next); then compound 1.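

In this assay, the equal numbers for phenyl and 2-phenylethenyl gave no sign that this saturated ring carbon is sensitive to its substituent, but 2,3,4-trimethoxyphenyl in place of 2-phenylethenyl gives a number 21.1 percentage points lower from compound 3 to compound 4 (beyond the scatter), and the same group in place of phenyl gives a number 21.1 percentage points lower from compound 2 to compound 4 (beyond the scatter). The 2,3,4-trimethoxyphenyl group therefore does not go with a high number in every setting: with that group held on this carbon, methyl in place of hydrogen on an oxygen on an aromatic ring gives a number 34.2 percentage points lower from compound 1 to compound 4 (beyond the scatter), which places the highest and lowest numbers of the series on one single change. No measurement on hand accounts for either drop.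

The compounds shown leave open whether the lower number in compound 4 follows from all three methoxy groups together or from fewer of them, and whether a group such as a pyridyl ring or a fluorophenyl on this carbon would fall with compound 4 or stay with compounds 2 and 3. Also open, going by these compounds, is whether the free hydroxyl of compound 1 would keep its number with phenyl or 2-phenylethenyl on the saturated ring carbon, or whether an amine there would change the picture.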